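Replacing a flexible chain with a cyclopentyl ring

A few compounds are considered here, and "the series" means these few. Any claim that something is new, unique, unknown or untested is made for them only; others in the source may bear on it.

Compound 1 `CCCCc1nc(/C=N/Nc2nc(N)c3ncn([C@@H]4O[C@H](CO)[C@@H](O)[C@H]4O)c3n2)c(Cl)[nH]1` and compound 2 `Nc1nc(N/N=C/c2ccc[nH]2)nc2c1ncn2[C@@H]1O[C@H](CO)[C@@H](O)[C@H]1O` share a core that carries a hydrazone-like arm. In an assay on CHO-K1 cells for displacement of a labelled ligand from adenosine receptor A1 (Homo sapiens), read by scintillation counting, with a stated time of 60 min (a lower number here means a stronger inhibitor, a higher number a weaker inhibitor), compound 1 gives 12 nM, and compound 2 gives 8 nM; a 1.5-fold lower number from compound 1 to compound 2 (0.18 log units; within the scatter) lies within the scatter. Compound 3 `CSCC/C=N/Nc1nc(N)c2ncn([C@@H]3O[C@H](CO)[C@@H](O)[C@H]3O)c2n1` carries a 2-(methylsulfanyl)ethyl chain in place of an aromatic ring on the carbon with a double bond to nitrogen. In this assay compound 3 gives only a limit of the assay, > 10000 nM, so its true value is not known, only that it sits at this limit (the limit of > 10000 nM in this assay, at which 1 of the 3 values shown sits).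

Compound 4 `Nc1nc(N/N=C/C2CCCC2)nc2c1ncn2[C@@H]1O[C@H](CO)[C@@H](O)[C@H]1O` differs from compound 3 in one place: cyclopentyl in place of 2-(methylsulfanyl)ethyl on a carbon with a double bond to nitrogen. Going by the values given here, the steps that bear on this change are an at least 830-fold higher number from compound 1 to compound 3 (2.92 log units; beyond the scatter) and an at least 1200-fold higher number from compound 2 to compound 3 (3.09 log units; beyond the scatter), both large, showing that the chain is far weaker than either aromatic ring. Cyclopentyl is a ring, but a non-aromatic one, so compound 4 is expected to recover only part of that loss, with an estimated at least 3.3-fold lower number from compound 3 to compound 4 (0.52 log units; beyond the scatter). Compound 4 is therefore expected to give about 3000 nM in this assay, in a range from 300 nM to 20000 nM.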

Compound 4, inhibition constant: 5.6 nM
Estimate against measurement, compound 4: 540-fold (2.73 log units) above, and the stated range ends above it.
By their numbers in this assay, from the lowest: compounds 4, 2 and 1 (each within the scatter of the next, the first and the last beyond it). At a limit, above all of these: compound 3.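

The carbon with a double bond to nitrogen does not need an aromatic ring to give a low number in this assay: the non-aromatic cyclopentyl of compound 4 cannot be told apart from the 1H-pyrrol-2-yl ring of compound 2 (a 1.4-fold lower number from compound 2 to compound 4 (0.15 log units; within the scatter)), and it shows a modest edge over the larger substituted ring of compound 1 (a 2.1-fold lower number from compound 1 to compound 4 (0.33 log units; beyond the scatter)). The sharp divide among these four compounds therefore lies between the three that carry a ring here and the open 2-(methylsulfanyl)ethyl chain, as an at least 1700-fold lower number from compound 3 to compound 4 (3.25 log units; beyond the scatter) shows. The size of that last step is itself only a bound, as the value of compound 3 is a limit and not a number: the limit of > 10000 nM in this assay, at which 1 of the 4 values shown sits.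

Compound 4 differs from compound 3 both in having a ring and in having no sulfur, and the compounds shown cannot separate these two changes, which an open butyl or pentyl chain of carbon only would begin to do. Going by these compounds, it also remains open whether a larger cyclohexyl ring, or an amine or a carboxylic acid on the cyclopentyl ring, would keep the number this low.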